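The source may report more compounds than this note shows. Statements on the series, on what has been measured and on what is new or still open speak of the compounds shown alone.

Compound 1 `O=C1COc2ccc(-c3[nH]c(-c4ccc(F)cc4)nc3-c3ccccc3)cc2N1` is the reference point of this set. For the measured compounds named here, in a functional assay on MV4-11 cells (Homo sapiens) for cytotoxicity, read by colorimetric assay and MTT assay, with a stated time of 3 days, tested at 20 uM (a lower number here means a stronger effect, a higher number a weaker effect of the compound at the concentration tested), compound 1 gives 1.1%, the lowest of the three numbers measured so far. The two others do not share the core of compound 1: compound 2 `O=C1COc2ccc(-c3nn(-c4ccc(Cl)cc4)cc3-c3ccccc3)cc2N1` gives 91.9% and compound 3 `O=C1COc2ccc(-c3nn(-c4ccccc4)cc3-c3ccccc3)cc2N1` gives 97.9%, both far above compound 1, beyond the scatter. Going by the values given here, the only step between measured compounds is a number 6 percentage points higher from compound 2 to compound 3 (within the scatter), and it changes a substituent on the pendant aryl of compound 2, much as the change below alters the pendant aryl of compound 1; it suggests that swapping a halogen for hydrogen there leaves the read-out unchanged, but it is on a different core and at the weak end of the scale, so it gives no direct guide to a move from a strong number.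

Compound 4 `O=C1COc2ccc(-c3[nH]c(-c4ccc(Cl)cc4Cl)nc3-c3ccccc3)cc2N1` carries 2,4-dichlorophenyl in place of 4-fluorophenyl on an aromatic carbon. Among the compounds with values here, no measured step bears directly on this change on the core of compound 1. The expectation is therefore that compound 4 stays near compound 1, with a step of a number 8.9 percentage points higher from compound 1 to compound 4 (within the scatter), and the range is kept wide upward because a loss of effect cannot be ruled out from the data. For compound 4 the estimated read-out is 10%, between 1% and 45%.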

Compound 4, a percentage reported as activity, at one concentration (the size of the read-out at that concentration, not a potency): 41.1%
Compound 4: middle estimate off by 31.1 percentage points, on the low side; measured number inside the range.
By their numbers in this assay, from the lowest: compound 1; then compound 4; then compounds 2 and 3 (each within the scatter of the next).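

On the core of compound 1, the aryl group on the ring carbon between two ring nitrogen atoms is not a silent place in this assay: putting 2,4-dichlorophenyl in place of 4-fluorophenyl gives a number 40 percentage points higher from compound 1 to compound 4 (beyond the scatter) and so moves the read-out beyond the scatter. For the compounds shown here, the only earlier step, on a different core and at the weak end of the scale, was a number 6 percentage points higher from compound 2 to compound 3 (within the scatter) and stayed within the scatter, so this is the first sign that the pendant aryl matters where the effect is strong. Nothing on hand gives a reason for the size of the new step.

The two groups differ in both the kind and the count of halogen, and this single step does not separate the two, which leaves 4-chlorophenyl and plain phenyl on the shared core as the obvious open comparisons. Also open, going by these compounds, is whether a pyridyl ring, or a phenyl carrying an amine or a carboxylic acid, at this place keeps the read-out near that of compound 1 at 1.1% or moves it as far as the dichloro change did.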